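Thiophene for benzofuran on the shared nucleoside core

The source may hold more compounds than are shown below. What is called first, only, known or untested is meant among the compounds shown, and "the series" means these compounds.

Measured so far:
compound 1, `Nc1nc(N)c2c(-c3ccsc3)cn([C@@H]3O[C@H](CO)[C@@H](O)[C@H]3O)c2n1`: in a functional assay on HL-60 cells (Homo sapiens) for antiproliferative activity, read by XTT assay, with a stated time of 72 h (on this read-out higher numbers stand for weaker inhibition and lower numbers for stronger inhibition), compound 1 gives > 20000 nM, a limit of the assay.
compound 2, `O=c1[nH]cnc2c1c(-c1cc3ccccc3o1)cn2[C@@H]1O[C@H](CO)[C@@H](O)[C@H]1O`: in this assay compound 2 gives > 20000 nM, a limit of the assay.

Compound 2 stands at the limit rather than at a number. Within the data shown here, compound 1 sits at the same limit, so both values shown are limits the limit of > 20000 nM in this assay, at which 2 of the 2 values shown sit, and no step between measured compounds can be given; the two limits only show that neither compound reaches a measurable value. Compound 3, `O=c1[nH]cnc2c1c(-c1ccsc1)cn2[C@@H]1O[C@H](CO)[C@@H](O)[C@H]1O`, differs from compound 2 by thiophen-3-yl in place of 1-benzofuran-2-yl on an aromatic carbon. Compound 1 carries the same thiophen-3-yl group on its own core and also sits at the limit. The step this estimate means, a step that the limit leaves unreadable from compound 2 to compound 3, is expected to be none beyond the scatter. Compound 3 is expected at about 25000 nM, within 10000 nM to 60000 nM, and most probably is reported again only as a limit.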

Compound 3, half-maximal inhibitory concentration: 12000 nM
Estimate against measurement, compound 3: 2.1-fold (0.32 log units) above; the range from low to high includes it.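

On the shared core, this aromatic carbon now yields a readable value in this assay: compound 3 gives 12000 nM. Thiophen-3-yl in place of 1-benzofuran-2-yl gives an at least 1.6-fold lower number from compound 2 to compound 3 (0.22 log units; that floor lies within the scatter), so the change is compatible with a measurable antiproliferative effect, but its floor does not establish a gain. The true size of the step stays unknown because compound 2 stands only at a limit of the assay: the limit of > 20000 nM in this assay, at which 2 of the 3 values shown sit.

The two groups differ both in ring count and in hetero atom, so the compounds shown do not separate these features; furan-3-yl or phenyl on the same carbon would bear on that. From the compounds shown here alone, whether a basic aminomethyl group or a carboxylic acid at this carbon would move the value also stays open.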